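Forecast for Compound 4 from Three Measured Analogues

The source may hold more compounds than are shown below. What is called first, only, known or untested is meant among the compounds shown, and "the series" means these compounds.

Compound 1, `C=CCn1c(=O)/c(=C\c2ccccc2Cl)[nH]c(=O)/c1=C\c1ccccc1OC`: 4400 nM
Compound 2, `C=CCn1c(=O)/c(=C\c2cccc(Cl)c2Cl)[nH]c(=O)/c1=C\c1ccccc1OC`: 1200 nM
Compound 3, `C=CCn1c(=O)/c(=C\c2cccc(Br)c2)[nH]c(=O)/c1=C\c1ccccc1OC`: 5000 nM

All three were tested in a functional assay on MOLT-4 cells (Homo sapiens) for cytotoxicity, read by CCK-8 assay, with a stated time of 72 h; on this read-out lower numbers stand for stronger inhibition and higher numbers for weaker inhibition. Compound 3 gives the highest of the three numbers; its nearest neighbour is compound 1, a 1.1-fold higher number from compound 1 to compound 3 (0.06 log units; within the scatter), while compound 2 lies furthest away, a 4.2-fold higher number from compound 2 to compound 3 (0.62 log units; beyond the scatter). For the measured compounds named here, the only measured step beyond the scatter is a 3.7-fold lower number from compound 1 to compound 2 (0.56 log units; beyond the scatter).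

Compound 4 is `C=CCn1c(=O)/c(=C\c2ccccc2C(F)(F)F)[nH]c(=O)/c1=C\c1ccccc1OC`. It differs from compound 3 in one place: 2-(trifluoromethyl)phenyl in place of 3-bromophenyl on a double-bonded chain carbon bound to an aromatic carbon. Going by the values given here, no measured pair involves a trifluoromethyl group, so the step has no direct precedent. The step from compound 1 to compound 3 shows that exchanging 2-chlorophenyl for 3-bromophenyl stays within the scatter, and only the second chlorine in compound 2 moved the number. Compound 4 is therefore expected to remain close to the measured neighbours, with any lowering uncertain. For compound 4 the expected step is a 1.4-fold lower number from compound 3 to compound 4 (0.15 log units; within the scatter). The estimate for compound 4 in this assay is 3500 nM, within a range from 1200 nM to 9000 nM.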

Compound 4, half-maximal inhibitory concentration: 4400 nM
The estimate for compound 4 lay 1.3-fold (0.10 log units) below the measured number; the range from low to high includes it.
By their numbers in this assay, from the lowest: compound 2; then compounds 1, 4 and 3 (each within the scatter of the next).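

In this assay, 2-(trifluoromethyl)phenyl at this place behaves like the two other singly substituted phenyl groups: trifluoromethyl in place of chloro gives (no change at the digits printed from compound 1 to compound 4 (within the scatter)), and the exchange for 3-bromophenyl gives (a 1.1-fold lower number from compound 3 to compound 4 (0.06 log units; within the scatter)). Compounds 1, 3 and 4 thus all lie within the scatter of one another, so a chloro, a bromo and a trifluoromethyl substituent are not told apart here, while compound 2, with its 2,3-dichlorophenyl group, goes against this sameness (a 3.7-fold higher number from compound 2 to compound 4 (0.56 log units; beyond the scatter)). Nothing available explains why these groups give such similar numbers.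

From the compounds shown here alone, it remains open whether adding a chloro to the 2-(trifluoromethyl)phenyl group would lower the number as the second chlorine did in compound 2. Going by these compounds, it is also open whether a phenyl group carrying an amine or a carboxylic acid would stay with compounds 1, 3 and 4.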